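The compounds below may be only part of what the source reports. "The series", "measured", "known", "first", "only" and "open" are said of these compounds alone.

Compound 1 `Cc1ccc(N(CCN2CCC(OCC(=O)O)CC2)C(=O)c2ccc(C(F)(F)F)cc2)cc1`: > 10000 nM, a limit
Compound 2 `Cc1ccc(N(CCN2CCC(OCC(=O)O)CC2)C(=O)c2ccc(-c3ccccc3)cc2)cc1`: > 10000 nM, a limit
Compound 3 `O=C(O)COC1CCN(CCN(C(=O)c2ccc(Cl)cc2)c2ccc(Cl)cc2)CC1`: 1500 nM

All three compounds were tested in a functional assay on a cell-free system (Platelet, plasma, Homo sapiens) for inhibition; on this read-out lower numbers stand for stronger inhibition and higher numbers for weaker inhibition. In this assay, compound 1 stands at > 10000 nM, which is a limit and not a number.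

Compound 4 `COc1ccc(OC)c(C(=O)N(CCN2CCC(OCC(=O)O)CC2)c2ccc(C)cc2)c1` keeps the rest of compound 1 and changes the group on the carbonyl carbon: 2,5-dimethoxyphenyl in place of 4-(trifluoromethyl)phenyl on a carbonyl carbon. The closest measured change is a step that the two limits leave unreadable from compound 1 to compound 2, so it gives no size to carry over. The other guide is the limit of > 10000 nM in this assay, at which 2 of the 3 values shown sit. Compound 4 is therefore expected to stay weak in this assay, with no step beyond the scatter and a limit quite possible. The expected step is a number no higher from compound 1 to compound 4 (the limit leaves the size open). For compound 4 the estimate is 10000 nM, with an expected range from 2500 nM to 30000 nM.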

Compound 4, half-maximal inhibitory concentration: > 3000 nM
Compound 4: no number, only a limit; the forecaster's own chance of this, stated with the estimate: 60%; the middle value is on the limit's open side.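

Within the data shown here, compound 1 and compound 4 both carry only limits in this assay, and no step between them can be read. The compounds shown leave open whether 2,5-dimethoxyphenyl in place of 4-(trifluoromethyl)phenyl changes inhibition at all.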